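The compounds below may be only part of what the source reports. "The series", "measured", "known", "first", "only" and "open" are said of these compounds alone.

Working notes on the series.

Three compounds share one core and have been run in a functional assay on NCI-H1581 cells (Homo sapiens) for inhibition, read by MTT assay, with a stated time of 48 h, tested at 10 uM; a higher number here means more inhibition at the concentration tested (going by the name of the read-out), a lower number less inhibition. Compound 1 `CCc1ccc(Nc2cc(NC(=O)Nc3c(Cl)cccc3Cl)ncn2)cc1` gives 38.1% in this assay. For the measured compounds named here, compound 2 `COc1ccc(F)cc1Nc1cc(NC(=O)Nc2c(Cl)cccc2Cl)ncn1` gives 73.1% in this assay, and the single change between them, 5-fluoro-2-methoxyphenyl in place of 4-ethylphenyl on a nitrogen on an aromatic ring, carries a number 35 percentage points higher from compound 1 to compound 2 (beyond the scatter). Compound 3 `COc1cc(NC(=O)Nc2cc(Nc3ccc(C)c(F)c3)ncn2)cc(OC)c1` gives 38% in this assay, the lowest of the three numbers, though within the scatter of compound 1; only compound 2 stands clearly apart from it.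

The next compound, compound 4 `COc1cc(NC(=O)Nc2cc(Nc3ccc(C(C)(C)C)cc3)ncn2)cc(OC)c1`, differs from compound 3 in one place: 4-(tert-butyl)phenyl in place of 3-fluoro-4-methylphenyl on a nitrogen on an aromatic ring. Going by the values given here, the only measured step at this nitrogen is the one from compound 1 to compound 2, which was large and ran upward when a 4-alkylphenyl was replaced by a fluorinated methoxyphenyl. Compound 4 moves the other way, back toward a 4-alkylphenyl like that of compound 1, and compound 1 sits low. Compound 3 is already among the low numbers, so no step beyond the scatter is expected, if anything a slight fall.

The estimated step from compound 3 to compound 4 is a number 6 percentage points lower from compound 3 to compound 4 (within the scatter) in this assay. Compound 4 is therefore expected to give about 32% in this assay, within roughly 15% to 55%.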

Compound 4, a percentage reported as inhibition, at one concentration (the size of the read-out at that concentration, not a potency): 38.7%
For compound 4 the middle estimate is 6.7 percentage points below the measured one, within the range that was stated.
By their numbers in this assay, from the lowest: compounds 3, 1 and 4 (each within the scatter of the next); then compound 2.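

In this assay, exchanging 3-fluoro-4-methylphenyl for 4-(tert-butyl)phenyl on a nitrogen on an aromatic ring gives a number 0.7 percentage points higher from compound 3 to compound 4 (within the scatter). Unlike the only earlier step at this position, this one is read with the remainder of compound 3 held fixed, and it shows that this change, from 8 heavy atoms including one fluorine to 10 carbon atoms, gives no readable change in the number at the concentration tested. The compounds shown offer no measurement that could explain this absence of a readable change.

For the compounds shown here, the large rise seen with the other remainder, a number 35 percentage points higher from compound 1 to compound 2 (beyond the scatter), has no counterpart here, so it stays open whether 5-fluoro-2-methoxyphenyl on this nitrogen would give a similar rise with the remainder of compound 3 in place. Also open, going by these compounds, is how the number would respond to a ring on this nitrogen bearing an amine or a carboxylic acid, as every aromatic ring at this position here carries only alkyl, fluorine or methoxy substituents.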